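The source may hold more compounds than are shown below. What is called first, only, known or untested is meant among the compounds shown, and "the series" means these compounds.

Three compounds have been measured in a functional assay on KB cells (Homo sapiens) for antiproliferative activity, read by sulforhodamine B assay, with a stated time of 3 days; on this read-out lower numbers stand for stronger inhibition of growth and higher numbers for weaker inhibition of growth:

Compound 1 `O=C(c1cccc(Nc2ncc(F)c(Nc3ccc(F)cc3)n2)c1)N1CCCCC1` gives 14800 nM.
Compound 2 `O=C(NCCO)c1cccc(Nc2ncc(F)c(Nc3ccc(F)cc3)n2)c1` gives 12400 nM.
Compound 3 `O=C(Nc1ccccn1)c1cccc(Nc2ncc(F)c(Nc3ccc(F)cc3)n2)c1` gives 20000 nM.

All three share the same core and differ only in the group attached on a carbonyl carbon. The step from compound 1 to compound 3 is a 1.4-fold higher number from compound 1 to compound 3 (0.13 log units; within the scatter), and the step from compound 2 to compound 3 is a 1.6-fold higher number from compound 2 to compound 3 (0.21 log units; within the scatter), so compound 3 sits together with the other two rather than apart from them. Compound 4 `COCC(=O)Nc1cccc(Nc2ncc(F)c(Nc3ccc(F)cc3)n2)c1` has not yet been measured. It differs from compound 3 as follows: ((methoxymethyl)carbonyl)amino in place of (pyridin-2-yl)carbamoyl on an aromatic carbon. Within the data shown here, none of the measured steps covers this kind of change, since each of them, including a 1.2-fold lower number from compound 1 to compound 2 (0.08 log units; within the scatter), only exchanges the group on a carbonyl carbon. What those steps do show is that three different groups at that place gave numbers that stayed within the scatter of one another. The expected step is therefore a 1.3-fold lower number from compound 3 to compound 4 (0.12 log units; within the scatter), meaning no change beyond the scatter. Compound 4 is estimated at 15000 nM, with a likely range from 5000 nM to 40000 nM.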

Compound 4, concentration for 50% growth inhibition: 6250 nM
Estimate against measurement, compound 4: 2.4-fold (0.38 log units) above, within the range that was stated.
By their numbers in this assay, from the lowest: compounds 4, 2, 1 and 3 (each within the scatter of the next, the first and the last beyond it).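

Among these compounds, changing how the group is attached to the aromatic carbon matters more than anything seen so far: exchanging groups on the carbonyl carbon left all three numbers within the scatter, whereas the ((methoxymethyl)carbonyl)amino group gives the first steps beyond it, a 3.2-fold lower number from compound 3 to compound 4 (0.51 log units; beyond the scatter) and a 2.4-fold lower number from compound 1 to compound 4 (0.37 log units; beyond the scatter), both modest. The effect is not uniform, since the remaining step, a 2.0-fold lower number from compound 2 to compound 4 (0.30 log units; within the scatter), does not separate compound 4 from the compound carrying the (2-hydroxyethyl)carbamoyl group. Nothing shown explains why this change lowers the number against those two compounds.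

The compounds shown do not tell whether the amide's direction of attachment or the methoxymethyl part accounts for these steps, as both change together. Also open, going by these compounds, is how a simple amine, a carboxylic acid or a longer ether chain on that aromatic carbon would behave.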